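A few compounds are considered here, and "the series" means these few. Any claim that something is new, unique, unknown or untested is made for them only; others in the source may bear on it.

Measured so far:
compound 1, `O=C(/C=C/c1ccccc1)Nc1ccc2c(c1)COC2=O`: 7240 nM
compound 2, `O=C(/C=C/c1cccc(F)c1)Nc1ccc2c(c1)COC2=O`: 34 nM
compound 3, `O=C(/C=C/c1ccccc1Br)Nc1ccc2c(c1)COC2=O`: > 100000 nM

Three compounds share one core and differ only in the ring at the end of the chain. In a functional assay on cells (T-cell, Mus musculus) for inhibition (on this read-out lower numbers stand for stronger inhibition and higher numbers for weaker inhibition), compound 1 gives 7240 nM. Compound 2, which carries fluoro on that ring, gives 34 nM and so has the lowest number of the two that are numbers; the change is a 210-fold lower number from compound 1 to compound 2 (2.33 log units; beyond the scatter). Compound 3 gives only a limit, > 100000 nM, as the limit of > 100000 nM in this assay, at which 1 of the 3 values shown sits, records. The step of an at least 2900-fold higher number from compound 2 to compound 3 (3.46 log units; beyond the scatter) shows how far apart these two ring substituents lie.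

Compound 4, `CC(=O)Oc1cccc(/C=C/C(=O)Nc2ccc3c(c2)COC3=O)c1`, has not been measured. It differs from compound 2 by acetoxy in place of fluoro on an aromatic carbon. Among the compounds with values here, the steps that bear on this are the one from compound 1 to compound 2, which was large, and the step from compound 1 to compound 3, an at least 13-fold higher number from compound 1 to compound 3 (1.14 log units; beyond the scatter), where a larger halogen on another position gave a much higher number. Acetoxy is larger than fluoro, so a higher number than compound 2 is expected in this assay, though smaller than the collapse seen for compound 3. Compound 4 is therefore estimated at 600 nM, with a range from 60 nM to 10000 nM, meaning an expected step of an 18-fold higher number from compound 2 to compound 4 (1.25 log units; beyond the scatter).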

Compound 4, half-maximal inhibitory concentration: 30 nM
For compound 4 the middle estimate is 20-fold (1.30 log units) above the measured one, outside the stated range (below it).
By their numbers in this assay, from the lowest: compounds 4 and 2 (each within the scatter of the next); then compound 1. At a limit, above all of these: compound 3.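

In this assay the place on the ring meta to a large group accepts two very different groups: putting acetoxy, with 4 heavy atoms and 2 hydrogen-bond acceptors, where fluoro had a single atom and none gives a 1.1-fold lower number from compound 2 to compound 4 (0.05 log units; within the scatter) and so leaves the read-out unchanged. Measured against the bare ring of the shared core, the same place gives a 240-fold lower number from compound 1 to compound 4 (2.38 log units; beyond the scatter) for this compound, so the large step first seen with fluoro is not tied to fluoro alone, and two groups now agree on this place, with only compounds 2 and 4 to support that. No measurement shown here explains why fluoro and acetoxy match, so the match stands as an observation without a stated cause.

The compounds shown leave open how far this acceptance reaches, for instance whether an amine, a carboxylic acid or a longer chain at the same place would also keep the read-out in this range. They also leave open how bromo would behave at this place, since compound 3 carries it elsewhere on the ring and differs from compounds 2 and 4 in both group and position.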